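An Oxazole Replaces a Pyrazole With Both Anchors at the Limit

The compounds below may be only part of what the source reports. "The series", "measured", "known", "first", "only" and "open" are said of these compounds alone.

Compound 2 `CCc1c(OC)nc2nc(-c3cc(C)[nH]n3)cn2c1C` is known only by a limit: in a functional assay on the whole organism with Rattus norvegicus as the target (a lower number here means that less compound is needed, a higher number that more compound is needed for the effect), compound 2 gives > 50 mg/kg, a limit of the assay rather than a number. Compound 1 `CCc1c(OC)nc2nc(-c3n[nH]c(C)n3)cn2c1C` likewise gives > 50 mg/kg in this assay, also a limit. For the measured compounds named here, the one measured step, a step that the two limits leave unreadable from compound 1 to compound 2, stays unreadable, since both values sit at the limit of > 50 mg/kg in this assay, at which 2 of the 2 values shown sit. Compound 3 `CCc1c(OC)nc2nc(-c3cc(C)no3)cn2c1C` differs from compound 2 by 3-methyl-1,2-oxazol-5-yl in place of 5-methyl-1H-pyrazol-3-yl on an aromatic carbon. Going by the values given here, no measured step bears on this change, so no direction can be read from the data. Compound 3 is expected to give 50 mg/kg, between 20 mg/kg and 200 mg/kg, most likely again as a limit. The expected step of a number no higher from compound 2 to compound 3 (the limit leaves the size open) is estimated as none beyond the scatter.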

Compound 3, minimum effective dose: 50 mg/kg
The estimate for compound 3 equals the measured number at the digits printed; low and high end bracket the measured number.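

In this assay, for the compounds shown here, compound 3 gives 50 mg/kg, the only value shown that is a number rather than a limit, so 3-methyl-1,2-oxazol-5-yl is the one group at this aromatic carbon with a readable dose. The change gives a number no higher from compound 2 to compound 3 (the limit leaves the size open), and likewise a number no higher from compound 1 to compound 3 (the limit leaves the size open). Neither size can be read, because each comparison rests on a limit: the limit of > 50 mg/kg in this assay, at which 2 of the 3 values shown sit.

From the compounds shown here alone, whether a longer chain in place of the methyl on the 3-methyl-1,2-oxazol-5-yl, or an amine on that ring, would need less compound stays open.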